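Swapping an Ethynyl for Bromine on a Fused Core

The source may report more compounds than this note shows. Statements on the series, on what has been measured and on what is new or still open speak of the compounds shown alone.

Compound 1 `C#Cc1nc2ccccc2o1` carries an ethynyl group on a fused two-ring core. In a functional assay on HCT-116 cells (Homo sapiens) for cytotoxicity, with a stated time of 3 days (on this read-out lower numbers stand for stronger inhibition and higher numbers for weaker inhibition), compound 1 gives 11600 nM. Compound 2 `C#CCNC(=O)c1csc(C#C)n1` carries the same ethynyl group on a different five-membered ring that bears an amide chain; in this assay compound 2 gives 19200 nM, a number that lies within the usual scatter of the value for compound 1. The difference between the two cores is not broken down here.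

Compound 3 `C#CCNC(=O)c1csc(Br)n1` is compound 2 with bromo in place of ethynyl. In this assay compound 3 reaches only a limit, > 40000 nM, and no number. The change is bromo in place of ethynyl on an aromatic carbon, and it made an at least 2.0-fold higher number from compound 2 to compound 3 (0.31 log units; beyond the scatter), a step whose size is known only as a floor because of the limit of > 40000 nM in this assay, at which 1 of the 3 values shown sits.

Compound 4 `Brc1nc2ccccc2o1` is compound 1 with the same kind of change, (bromo in place of ethynyl on an aromatic carbon). Here the place is a ring with one nitrogen and one oxygen inside a fused system, whereas the earlier place was a ring with one nitrogen and one sulfur and lay two ring bonds from a six-atom group; so the surroundings differ, and the two changes are of the same kind rather than identical.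

Compound 4 is expected to be weaker than compound 1 by about a 3.0-fold higher number from compound 1 to compound 4 (0.48 log units; beyond the scatter), resting on the direction seen from compound 2 to compound 3 in an at least 2.0-fold higher number from compound 2 to compound 3 (0.31 log units; beyond the scatter). Compound 4 is estimated at 35000 nM, with a likely range from 15000 nM to 90000 nM.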

Compound 4, half-maximal inhibitory concentration: > 40000 nM
Compound 4 ended at the assay's limit; the forecaster's own chance of this, stated with the estimate: 45%; middle value at least 1.1-fold (0.05 log units) away from the limit.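

Compound 4 reaches only > 40000 nM in this assay, which is a limit of the assay and not a number. Bromo in place of ethynyl gives an at least 3.4-fold higher number from compound 1 to compound 4 (0.53 log units; beyond the scatter), and the same kind of change on the other core points the same way, so within these two pairs the direction carries over from one core to the other: the same change on two cores in this assay, an at least 2.0-fold higher number (0.31 log units; beyond the scatter) from compound 2 to compound 3 and an at least 3.4-fold higher number (0.53 log units; beyond the scatter) from compound 1 to compound 4; the limit leaves it open whether they differ The size of the change cannot be compared in any exact way, since neither bromo compound has a number, and two pairs on two cores make no general rule for other cores in the series: the limit of > 40000 nM in this assay, at which 2 of the 4 values shown sit.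

The compounds shown leave open how other small groups would read at this same place on either core, such as a chloro group, a nitrile, a methyl group or an amine, since only ethynyl and bromo appear there. They also leave open what the amide chain of compound 2 would do if it were set on the core of compound 1, and how far beyond the limit the two bromo compounds really lie.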